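Cyclopropyl for 2-methoxyphenyl on the shared core

The compounds below may be only part of what the source reports. "The series", "measured", "known", "first", "only" and "open" are said of these compounds alone.

In a physicochemical assay for lipophilicity, read by HPLC, at pH 7.4 (a higher number here means a more lipophilic compound, a lower number a more polar compound), compound 3 `CCC/N=C1\S/C(=C\c2ccc(O)c(Cl)c2)C(=O)N1c1ccccc1OC` gives 3.3 as the highest of three numbers, above compound 2 `CCC/N=C1\S/C(=C\c2ccc(O)c(Cl)c2)C(=O)N1c1ccccc1O` at 2.7 and compound 1 `CCC/N=C1\S/C(=C\c2ccc(O)c(Cl)c2)C(=O)N1C1CCN(C)C(=O)C1` at 0.6 in this series. The change to unmeasured compound 4 `CCC/N=C1\S/C(=C\c2ccc(O)c(Cl)c2)C(=O)N1C1CC1` is cyclopropyl in place of 2-methoxyphenyl, counted as cyclopropyl in place of 2-methoxyphenyl on an amide-type nitrogen in a ring on the shared core. For the measured compounds named here, no measured step makes this exact exchange. The nearest are two large steps at the same place, a number 2.70 log units higher from compound 1 to compound 3 (beyond the scatter) and a number 2.10 log units higher from compound 1 to compound 2 (beyond the scatter) on the same nitrogen, plus the modest step of a number 0.60 log units higher from compound 2 to compound 3 (beyond the scatter) inside the leaving group. The estimated step, an expected modest fall smaller than the large steps, is a number 0.50 log units lower from compound 3 to compound 4 (beyond the scatter) in this assay readings. Compound 4 is expected at 2.8 within an estimated range from 2.2 to 3.3 once measured.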

Compound 4, distribution coefficient: 3.4
Beside the measured number, compound 4's estimate is 0.60 log units below it; the whole stated range lies below it.
By their numbers in this assay, from the lowest: compound 1; then compound 2; then compounds 3 and 4 (each within the scatter of the next).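

In this assay, this position on the amide-type nitrogen in a ring holds its reading when 2-methoxyphenyl, with 8 heavy atoms and an aromatic ring, gives way to cyclopropyl, with 3 heavy atoms, as the step is a number 0.10 log units higher from compound 3 to compound 4 (within the scatter). The same cyclopropyl stands apart from the other two groups at this nitrogen, with steps of a number 0.70 log units higher from compound 2 to compound 4 (beyond the scatter) and a number 2.80 log units higher from compound 1 to compound 4 (beyond the scatter). Nothing available here bears on the reason for this pattern.

The compounds shown leave open how a cyclohexyl ring, a longer alkyl chain, or a group carrying an amine or a carboxylic acid would read at this nitrogen.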